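Series notes: from compound 3 to compound 4

This account rests on a few compounds, and the source may have more. Where it says the series, first, only, none or still open, it means among the compounds named here.

Measured so far in a functional assay on HCT-116 cells (Homo sapiens) for inhibition, read by sulforhodamine B assay, with a stated time of 2 days; on this read-out lower numbers stand for stronger inhibition of growth and higher numbers for weaker inhibition of growth
- compound 1 `CC1=C(C(=O)Nc2cccc([N+](=O)[O-])c2)C(c2ccc(O)cc2O)NC(SCc2ccccc2)=N1` gives 29000 nM
- compound 2 `CC1=C(C(=O)Nc2cccc([N+](=O)[O-])c2)C(c2ccc(O)cc2O)NC(Nc2ccc([N+](=O)[O-])cc2Cl)=N1` gives 10900 nM
- compound 3 `CC1=C(C(=O)Nc2cccc([N+](=O)[O-])c2)C(c2ccc(O)cc2O)NC(NN)=N1` gives 47700 nM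

Compound 3, with 47700 nM, sits at the weak end of this small set. The measured step of a 1.6-fold higher number from compound 1 to compound 3 (0.22 log units; within the scatter) lies within the scatter, while the step of a 4.4-fold higher number from compound 2 to compound 3 (0.64 log units; beyond the scatter) lies beyond it.

In compound 4 `CC1=C(C(=O)Nc2cccc([N+](=O)[O-])c2)C(c2ccc(O)cc2O)NC(N/N=C/c2ccco2)=N1`, not yet measured, the amino is replaced on an amine nitrogen. The change is a group of 7 heavy atoms (5 carbon, 1 nitrogen, 1 oxygen; one five-membered aromatic ring with 1 hetero atom) in place of one nitrogen atom, on an amine nitrogen and the entering group holds one five-membered aromatic ring with 1 hetero atom.

Going by the values given here, two measured steps bear on this. The step of a 4.4-fold higher number from compound 2 to compound 3 (0.64 log units; beyond the scatter) puts amino in place of 2-chloro-4-nitrophenyl on an amine nitrogen, and read in reverse it points to a lower number once a ring-bearing group returns. The step of a 1.6-fold higher number from compound 1 to compound 3 (0.22 log units; within the scatter) goes against any general rule, since benzylsulfanyl also bears a ring and is not separated from the amino-bearing compound. Neither group matches the one entering here, so the guide is indirect.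

A modest drop is therefore expected in this assay, an estimated 2.4-fold lower number from compound 3 to compound 4 (0.38 log units; beyond the scatter) and no more than that. The estimate for compound 4 is 20000 nM, with an expected range from 9000 nM to 45000 nM as the outcome.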

Compound 4, concentration for 50% growth inhibition: 8890 nM
Compound 4: middle estimate off by 2.2-fold (0.35 log units), on the high side, outside the stated range (below it).
By their numbers in this assay, from the lowest: compounds 4 and 2 (each within the scatter of the next); then compounds 1 and 3 (each within the scatter of the next).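

In this assay, replacing the amino on this amine nitrogen with the group of 7 heavy atoms holding one five-membered aromatic ring with 1 hetero atom gives a 5.4-fold lower number from compound 3 to compound 4 (0.73 log units; beyond the scatter) and so shows that a second ring-bearing group, quite unlike 2-chloro-4-nitrophenyl, also lowers the number at this place. The two ring-bearing groups on the amine nitrogen are not separated, with a 1.2-fold lower number from compound 2 to compound 4 (0.09 log units; within the scatter) despite their different rings, so the chlorine and nitro of compound 2 are not needed to reach this level in the pair. The comparison with the benzylsulfanyl on the carbon with a double bond to nitrogen gives a 3.3-fold lower number from compound 1 to compound 4 (0.51 log units; beyond the scatter), and compound 1 stands against any rule that a ring alone lowers the number, since it also bears a ring yet is not separated from compound 3.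

Going by these compounds, it remains open whether the ring or the double bond outside aromatic rings accounts for the step from the amino, and a plain methyl or a phenyl on that same carbon of the entering group would help to divide the two. No measured evidence on the cause of these steps is at hand.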